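Two-part hydrazone amides: swapping the benzoyl group

This account rests on a few compounds, and the source may have more. Where it says the series, first, only, none or still open, it means among the compounds named here.

Compound 1 `CN(C(=O)NC(=O)c1ccc(F)c(F)c1)c1nc(C(F)(F)F)c(C(=O)N/N=C/c2ccc(C(F)(F)F)cc2)s1` and compound 2 `CN(C(=O)NC(=O)c1cccc(C(F)(F)F)c1)c1nc(C(F)(F)F)c(C(=O)N/N=C/c2ccccc2C(F)(F)F)s1` share a core and differ at both ends, in the acyl group on the urea and in the ring of the hydrazone. In a functional assay on A549 cells (Homo sapiens) for inhibition, read by MTT assay, with a stated time of 72 h (a higher number here means a weaker inhibitor, a lower number a stronger inhibitor), compound 1 gives 6.07 ug/mL and compound 2 gives 12.1 ug/mL. The two numbers lie within the usual scatter of each other, so no order between compound 1 and compound 2 is claimed on these data; compound 2 is simply the later of the two values at hand, and nothing here separates it from compound 1.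

Compound 3 `CN(C(=O)NC(=O)c1ccc(F)c(F)c1)c1nc(C(F)(F)F)c(C(=O)N/N=C/c2ccccc2C(F)(F)F)s1` is not yet measured. It keeps the hydrazone part of compound 2 and changes only the acyl group: 3,4-difluorophenyl in place of 3-(trifluoromethyl)phenyl on a carbonyl carbon. Among the compounds with values here, no measured pair isolates this exchange, so its effect can only be inferred. Compound 1 carries the same 3,4-difluorophenyl carbonyl and gives 6.07 ug/mL in this assay, which speaks for a number of the same order. The step from compound 2 to compound 3 is expected to be small, a 1.5-fold lower number from compound 2 to compound 3 (0.18 log units; within the scatter), towards a lower number or none beyond the scatter. Compound 3 is estimated at 8 ug/mL, within 3 ug/mL to 20 ug/mL.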

Compound 3, half-maximal inhibitory concentration: 6.96 ug/mL
Compound 3: middle estimate off by 1.1-fold (0.06 log units), on the high side; low and high end bracket the measured number.
By their numbers in this assay, from the lowest: compounds 1, 3 and 2 (each within the scatter of the next).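

In this assay, within the data shown here, the pair compound 2 and compound 3 isolates for the first time the exchange of 3-(trifluoromethyl)phenyl for 3,4-difluorophenyl on a carbonyl carbon, and it reads as a 1.7-fold lower number from compound 2 to compound 3 (0.24 log units; within the scatter), so this single change at this position does not separate the two compounds on these data. Compound 3 also supplies a second single-place comparison, this time at the other end of the molecule, where 2-(trifluoromethyl)phenyl in place of 4-(trifluoromethyl)phenyl on a carbon with a double bond to nitrogen reads as a 1.1-fold higher number from compound 1 to compound 3 (0.06 log units; within the scatter), so that exchange gives no separation either. No measurement at hand offers an explanation for either result.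

Both exchanges stay among phenyl rings carrying fluorine or trifluoromethyl, so the compounds shown do not tell whether a different kind of group on the same carbonyl carbon, such as a pyridine ring, a simple amine or a longer alkyl chain, would give a number beyond the scatter. Going by these compounds, it also remains open whether the same two exchanges would give the same reading on a different acyl group or hydrazone ring.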